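The compounds below may be only part of what the source reports. "The series", "measured", "known", "first", "only" and "open" are said of these compounds alone.

Of the compounds shown here, three sharing one core have so far been tested in a functional assay on MGC-803 cells (Homo sapiens) for inhibition, read by sulforhodamine B assay; a higher number here means a weaker inhibitor, a lower number a stronger inhibitor. Compound 1 `O=C1C(Nc2ccc(C(F)(F)F)cc2)=CC(=O)c2c1nc1n2[C@H]2OC[C@@H](O)[C@H]2OC1` gives 1860 nM, and compound 2 `COc1ccccc1NC1=CC(=O)c2nc3n(c2C1=O)[C@H]1OC[C@@H](O)[C@H]1OC3` gives 1630 nM. Compound 2 thus holds the lowest of the two numbers, but compound 1 sits within the scatter of it, so no order can be read between the two. Compound 3 `O=C1C(NC2CC2)=CC(=O)c2c1nc1n2[C@H]2OC[C@@H](O)[C@H]2OC1` is reported only as a limit, > 4000 nM, not as a number. Within the data shown here, the one step that can be sized, an at least 2.1-fold higher number from compound 1 to compound 3 (0.33 log units; beyond the scatter), shows that cyclopropyl in place of 4-(trifluoromethyl)phenyl on the amine nitrogen weakens inhibition, although the limit of > 4000 nM in this assay, at which 1 of the 3 values shown sits, leaves the full extent of that loss open.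

Compound 4 `O=C1C=C(Nc2ccccc2)C(=O)c2c1nc1n2[C@H]2OC[C@@H](O)[C@H]2OC1` has not yet been measured. It differs from compound 2 by hydrogen in place of methoxy on an aromatic carbon. Among the measured compounds shown here, no measured step removes a single group from the aryl ring; the nearest guide is that compound 1 and compound 2, which carry different groups on that ring, lie within the scatter of each other. The expectation for compound 4 is therefore no change beyond the scatter, a 1.1-fold higher number from compound 2 to compound 4 (0.04 log units; within the scatter). Compound 4 is estimated at 1800 nM in this assay, with a likely range from 900 nM to 3800 nM.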

Compound 4, half-maximal inhibitory concentration: 1730 nM
The estimate for compound 4 lay 1.0-fold (0.02 log units) above the measured number, and the stated range covers the measured number.
By their numbers in this assay, from the lowest: compounds 2, 4 and 1 (each within the scatter of the next). At a limit, above all of these: compound 3.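

Setting hydrogen in place of methoxy on the aromatic ring, which turns the 2-methoxyphenyl group into a plain phenyl, gives a 1.1-fold higher number from compound 2 to compound 4 (0.03 log units; within the scatter) in this assay. This is the first comparison shown that isolates a single group on this ring, and it shows that the methoxy group, at this place on the ring, is not needed to reach the level of inhibition seen for compound 2. Together with compound 1, which carries a 4-(trifluoromethyl)phenyl group and also stands within the scatter of compound 4, the three aryl compounds form one level of inhibition, and nothing shown explains why these different groups on the ring give numbers so close together.

On these data alone, compound 3 is reported only as a limit, > 4000 nM, so the size of its loss against the aryl compounds stays open. Also open, as far as these compounds go, is whether a group of another kind on the phenyl ring, such as an amine or a carboxylic acid, or a longer chain on the amine nitrogen, would move the number beyond the scatter.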